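One added methyl: ethyl becomes isopropyl

A few compounds are considered here, and "the series" means these few. Any claim that something is new, unique, unknown or untested is made for them only; others in the source may bear on it.

compound 1 `COc1ccc(-c2nc(C)nn2-c2cccc(C(=O)NCCCc3ccc(Br)cc3)c2)cc1` gives > 20000 nM
compound 2 `COc1ccc(-c2nc(C)nn2-c2cccc(C(=O)NCCOCc3ccccc3)c2)cc1` gives 9340 nM
compound 3 `CCc1nc(-c2ccc(OC)cc2)n(-c2cccc(C(=O)NCCCCc3ccccc3)c2)n1` gives 140 nM
compound 4 `COc1ccc(-c2nc(C(C)C)nn2-c2cccc(C(=O)NCCCCc3ccccc3)c2)cc1` is not yet measured

These values come from a functional assay on PANC-1 cells (Homo sapiens), read by microscopy, crystal violet staining and transwell migration, with a stated time of 18 h, in the presence of a further agent that is not named here (on this read-out higher numbers stand for weaker inhibition and lower numbers for stronger inhibition), and compound 3 at 140 nM holds the lower of the two true numbers, the other being compound 2 at 9340 nM in the same test. The entry for compound 1 at > 20000 nM is a limit of the assay, not a number.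

Compound 4 differs from compound 3 in a single place (methyl in place of hydrogen on a saturated chain carbon bound to an aromatic carbon and a saturated chain carbon) where ethyl becomes isopropyl. Within the data shown here, the only measured step (an at least 2.1-fold lower number from compound 1 to compound 2 (0.33 log units; beyond the scatter)) puts benzyloxy in place of 4-bromobenzyl and leaves this group untouched. Among the measured compounds shown here, no measured step therefore tests the change directly. For the measured compounds named here, it shows only that one change in these compounds can move the number beyond the scatter. The best anchor is compound 3 (140 nM) as the closest relative of compound 4. The expected size of the change (a 1.2-fold higher number from compound 3 to compound 4 (0.08 log units; within the scatter)) is small, perhaps within the scatter, with only a slight lean towards a higher number. In this assay the expected value for compound 4 is 170 nM (estimated range 45 nM to 650 nM).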

Compound 4, half-maximal inhibitory concentration: > 20000 nM
Compound 4 was reported as a limit (the forecaster's own chance of this, stated with the estimate: 3%); at least 110-fold (2.07 log units) between middle value and limit.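

The group at this place is far from a silent spectator: a single added methyl, turning ethyl into isopropyl, gives an at least 140-fold higher number from compound 3 to compound 4 (2.15 log units; beyond the scatter), a large step well beyond the scatter. Among these compounds, the one earlier step changed another part of the molecule, so this is the first direct evidence that so small a change here can nearly erase the activity seen for compound 3. For compound 4, the entry > 20000 nM is a limit of the assay, so the true size of the step stays unknown: the limit of > 20000 nM in this assay, at which 2 of the 4 values shown sit.

As far as these compounds go, what a propyl, a cyclopropyl or a tert-butyl group would do at this place remains open. So does the effect of a plain methyl here when the rest of the molecule matches compound 3, which would show whether ethyl itself is the better fit.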